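The source may hold more compounds than are shown below. What is called first, only, known or untested is meant among the compounds shown, and "the series" means these compounds.

Of the compounds shown here, three built on a shared core have been tested in a functional assay on SK-MEL cells (Homo sapiens) for cytotoxicity, read by MTT assay, with a stated time of 6 days; a lower number here means that less compound is needed, a higher number that more compound is needed for the effect. Compound 1 `COC(=O)c1c(-c2cc(OC)cc(OC)c2)oc2ccccc2c1=O` gave only a limit, > 25 ug/mL. From the compounds shown here alone, compound 2 `COC(=O)c1c(-c2ccc(Br)cc2)oc2ccccc2c1=O` also gave only a limit, > 25 ug/mL, so its true position is unknown. Going by the values given here, compound 3 `COC(=O)c1c(-c2ccc(OCc3ccccc3)cc2)oc2ccc(OC)cc2c1=O` is the only one with a real number, 20.9 ug/mL. Compound 4 `COC(=O)c1c(-c2ccc(O)cc2)oc2ccccc2c1=O` differs from compound 2 at one place, with hydroxy in place of bromo on an aromatic carbon, para to a large group: hydroxy in place of bromo on an aromatic carbon. Among the compounds with values here, no measured pair shows what this swap does, so no change beyond the scatter is expected in this assay. The expected move is a number no higher from compound 2 to compound 4 (the limit leaves the size open). For compound 4 the estimate is 25 ug/mL, with an expected range of 12 ug/mL to 50 ug/mL.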

Compound 4, concentration for half-maximal effect: > 25 ug/mL
Compound 4 ended at the assay's limit; the forecaster's own chance of this, stated with the estimate: 70%; the middle value sits exactly at the limit.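

Going by these compounds alone, compound 2 and compound 4 both gave only a limit, so no step between them can be read. From the compounds shown here alone, what hydroxy in place of bromo does in this assay, and the true number of either compound, stay open.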